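This account rests on a few compounds, and the source may have more. Where it says the series, first, only, none or still open, it means among the compounds named here.

Measured so far in a functional assay on WI-38 VA13 cells (Homo sapiens) for cytotoxicity; on this read-out lower numbers stand for an effect already at smaller amounts and higher numbers for an effect only at larger amounts of compound:

compound 1 `Cc1ncsc1CCOC(=O)c1oc2cc(-c3ccccc3)cc(O)c2c1C`: 0.055 ug/mL
compound 2 `Cc1c(C(=O)c2cnc3ccccc3c2)oc2cc(-c3ccccc3)cc(O)c12`: > 4 ug/mL, which is a limit of the assay rather than a number
compound 3 `COc1ccc(CCOC(=O)c2oc3cc(-c4ccccc4)cc(O)c3c2C)cc1OC`: 0.021 ug/mL

Compound 1 stands highest of the two numbers; compound 3 is nearest, with a 2.6-fold lower number from compound 1 to compound 3 (0.42 log units; beyond the scatter). For compound 2 only the limit is known, (the limit of > 4 ug/mL in this assay, at which 1 of the 3 values shown sits).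

Compound 4 `Cc1c(C(=O)Cc2ccccc2)oc2cc(-c3ccccc3)cc(O)c12` differs from compound 1 by benzyl in place of 2-(4-methyl-1,3-thiazol-5-yl)ethoxy on a carbonyl carbon. Among the measured compounds shown here, the only measured step, from compound 1 to compound 3, swapped a group on the saturated chain and kept the carbonyl's surroundings unchanged; no measured step touches the carbonyl carbon itself. The outcome for compound 4 is therefore uncertain, and a weaker effect is expected, an 18-fold higher number from compound 1 to compound 4 (1.26 log units; beyond the scatter). Compound 4 is estimated at 1 ug/mL, within 0.1 ug/mL to 4 ug/mL.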

Compound 4, half-maximal effective concentration: > 4 ug/mL
Compound 4: only a limit was reported; the forecaster's own chance of this, stated with the estimate: 30%; middle value at least 4.0-fold (0.60 log units) away from the limit.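

In this assay, the earlier step only swapped a group on the saturated chain, whereas this change on the carbonyl carbon has a large effect: an at least 72-fold higher number from compound 1 to compound 4 (1.86 log units; beyond the scatter). As far as these compounds go, compound 4 gives > 4 ug/mL, which is a limit of the assay and not a number, so the full size of the step stays unknown. Compound 2 also has only a limit, so two compounds shown lack an exact number: the limit of > 4 ug/mL in this assay, at which 2 of the 4 values shown sit.

This change replaces the linking oxygen, the chain and the ring together, so the compounds shown cannot separate their contributions. A methoxy or an amine on the same carbonyl carbon would help to tell them apart.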